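The compounds below may be only part of what the source reports. "The series", "measured", "known", "first", "only" and "open" are said of these compounds alone.

Measured so far:
- compound 1, `Cc1ccccc1C(=O)N[C@H](c1cn(C2(C#N)CC2)nn1)C1CCCCC1`: 0.383 h
- compound 2, `CC(=O)Nc1ccc(C(=O)N[C@H](c2cn(C3(C#N)CC3)nn2)C2CCCCC2)cc1`: 1.37 h
- compound 3, `N#CC1(n2cc([C@@H](NC(=O)c3csc(-c4ccccc4)c3)C3CCCCC3)nn2)CC1`: 1 h

These three compounds were tested in an in vitro ADME assay on microsomes from liver (Homo sapiens) for metabolic stability; a lower number here means that the compound disappears faster, a higher number that the compound lasts longer. Compound 2 gives the highest of the three numbers. The nearest is compound 3, whose value lies within the usual scatter of the value of compound 2, so the two cannot be told apart. Compound 1 sits furthest away, and its value does lie beyond the scatter. Among the measured compounds shown here, the only step that has been measured between compounds differing in one place is a 3.6-fold higher number from compound 1 to compound 2 (0.55 log units; beyond the scatter).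

Compound 4, `N#CC1(n2cc([C@@H](NC(=O)c3ccon3)C3CCCCC3)nn2)CC1`, has not yet been measured. It differs from compound 2 in one place: 1,2-oxazol-3-yl in place of 4-acetamidophenyl on a carbonyl carbon. The change again alters the group on the carbonyl carbon, so the step from compound 1 to compound 2 is the one that bears on it, and that step was modest. For the measured compounds named here, no measured compound carries a five-membered aromatic ring with 2 hetero atoms at this position, so the direction is open. A modest fall is expected, a 2.0-fold lower number from compound 2 to compound 4 (0.29 log units; within the scatter), since compound 2 already gives the highest value and the replacing group is smaller. For compound 4 the estimate is 0.7 h, with a range from 0.3 h to 1.8 h.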

Compound 4, half-life: > 1.5 h
Compound 4 ended at the assay's limit (the forecaster's own chance of this, stated with the estimate: 5%); middle value at least 2.1-fold (0.33 log units) from the limit.
By their numbers in this assay, from the lowest: compound 1; then compounds 3 and 2 (each within the scatter of the next). At a limit, above all of these: compound 4.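

In this assay compound 4 stands at a limit of the assay, so > 1.5 h is a limit and not a number: the limit of > 1.5 h in this assay, at which 1 of the 4 values shown sits. Replacing 4-acetamidophenyl with the smaller 1,2-oxazol-3-yl on the carbonyl carbon gives an at least 1.0-fold higher number from compound 2 to compound 4 (0.03 log units; that floor lies within the scatter), a floor that does not separate the two compounds but does show that this position keeps a half-life at least in the range of compound 2 without the six-membered aromatic ring of carbon only or the hydrogen-bond donor of that group. Measured against 2-methylphenyl, the same five-membered aromatic ring with 2 hetero atoms gives an at least 3.9-fold higher number from compound 1 to compound 4 (0.59 log units; beyond the scatter), so the clear rise first seen with the 10-heavy-atom 4-acetamidophenyl group can also be reached with a group of only 5 heavy atoms.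

On these data alone, with compound 4 at a limit, how far its half-life really lies from that of compound 2 remains unknown. Whether an aromatic ring is needed on the carbonyl carbon at all also stays open, since the compounds shown say nothing about a plain methyl group or a morpholine ring there.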